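Chloro in place of fluoro on the sulfonyl phenyl group

The compounds below may be only part of what the source reports. "The series", "measured", "known", "first", "only" and "open" are said of these compounds alone.

In an ADME assay on HEK-293T cells (Homo sapiens) for cytotoxicity, read by MTT assay, with a stated time of 24 h (a higher number here means that more compound is tolerated, a lower number that less compound is tolerated), compound 3 (`O=S(=O)(c1ccc(F)cc1)n1c(-c2cn(-c3ccccc3)nc2-c2ccc(F)cc2)nc2ccccc21`) gives 218000 nM and cannot be told apart within the scatter from compound 1 (`Cc1ccc(-c2nn(-c3ccccc3)cc2-c2nc3ccccc3n2S(=O)(=O)c2ccc(Cl)cc2)cc1`) at 167000 nM on this read-out. Among the measured compounds shown here, compound 2 (`Cc1ccc(C)c(S(=O)(=O)n2c(-c3cn(-c4ccccc4)nc3-c3ccc(F)cc3)nc3ccccc32)c1`) reads clearly lower at 54200 nM and is the one compound set apart from compound 3.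

Compound 4 (`O=S(=O)(c1ccc(Cl)cc1)n1c(-c2cn(-c3ccccc3)nc2-c2ccc(F)cc2)nc2ccccc21`) differs from compound 3 by chloro in place of fluoro on an aromatic carbon, para to a large group. For the measured compounds named here, the only measured step on the sulfonyl sulfur is a 4.0-fold higher number from compound 2 to compound 3 (0.60 log units; beyond the scatter) for 4-fluorophenyl in place of 2,5-dimethylphenyl. It is modest and involves a different group, so it bears only loosely on this change. Closer evidence comes from compound 1, which also carries the 4-chlorophenyl group on its sulfonyl sulfur and, despite differing elsewhere, sits at 167000 nM within the scatter of compound 3.

In this assay no step beyond the scatter is therefore expected, and the estimated step is a 1.2-fold lower number from compound 3 to compound 4 (0.08 log units; within the scatter) in size. The expected value for compound 4 is 180000 nM (estimated range 90000 nM to 360000 nM).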

Compound 4, half-maximal cytotoxic concentration: 93100 nM
Estimate against measurement, compound 4: 1.9-fold (0.29 log units) above; the range from low to high includes it.
By their numbers in this assay, from the lowest: compounds 2, 4, 1 and 3 (each within the scatter of the next, the first and the last beyond it).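

The exchange of fluoro for chloro on the sulfonyl phenyl group, a change of one heavy atom, gives a 2.3-fold lower number from compound 3 to compound 4 (0.37 log units; beyond the scatter) in this assay, so this position responds to the halogen alone and not only to the larger replacement seen earlier. That replacement now looks less clear-cut: 4-chlorophenyl in place of 2,5-dimethylphenyl gives a 1.7-fold higher number from compound 2 to compound 4 (0.23 log units; within the scatter), and fluoro in place of methyl on an aromatic carbon gives a 1.8-fold lower number from compound 1 to compound 4 (0.25 log units; within the scatter), so compound 4 cannot be separated from either compound 2 or compound 1. Nothing available accounts for the step from fluoro to chloro.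

As far as these compounds go, how a bromo, a methoxy group or an amine would read on this aromatic carbon remains open. Also open, from the compounds shown here alone, is whether fluoro to chloro gives a similar step when the rest of the molecule is that of compound 1.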